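The compounds below may be only part of what the source reports. "The series", "measured", "known", "first", "only" and "open" are said of these compounds alone.

Measured so far:
Compound 1, `Cc1cc(C(=O)O)nn1C(C)c1cc(Cl)ccc1OCc1ccccc1`, in a physicochemical assay for lipophilicity, at pH 7.4 (a lower number here means a more polar compound, a higher number a more lipophilic compound), gives 1.
Compound 2, `Cc1cc(C(=O)Nc2ccc(F)cc2)nn1Cc1cc(Cl)ccc1OCc1ccccc1`, in this assay gives 3.

Of the two compounds with a number, compound 2 stands highest, and its nearest neighbour is compound 1, whose value lies well beyond the scatter below it. For the measured compounds named here, no pair of measured compounds differing in just one place is available, so no measured step can be quoted.

The next compound, compound 3, `Cc1cc(C(=O)NCc2cccnc2)nn1Cc1cc(Cl)ccc1OCc1ccccc1`, differs from compound 2 in one place: (pyridin-3-yl)methyl in place of 4-fluorophenyl on an amide-type nitrogen. In words, (pyridin-3-yl)methyl takes the place of 4-fluorophenyl on the amide-type nitrogen, whose other neighbour is the carbonyl carbon. This change brings in one hydrogen-bond acceptor where the leaving group had none.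

For compound 3, a downward step of a number 1.50 log units lower from compound 2 to compound 3 (beyond the scatter) in this assay is expected, clearly beyond the scatter. The estimate for compound 3 in this assay is 1.5, with a range from 0.8 to 2.2.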

Compound 3, distribution coefficient: > 3.7
Compound 3: only a limit was reported; the forecaster's own chance of this, stated with the estimate: 0%; middle value at least 2.20 log units away from the limit.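

Moving from 4-fluorophenyl to (pyridin-3-yl)methyl on the amide-type nitrogen gives a number at least 0.70 log units higher from compound 2 to compound 3 (beyond the scatter), the first measured step at this position. In this assay compound 3 gives > 3.7, which is a limit of the assay and not a number. So the hydrogen-bond acceptor counted in the entering group does not go with a lower number here, though the true size of the step stays unknown and the comparison rests on a single limit: the limit of > 3.7 in this assay, at which 1 of the 3 values shown sits.

The entering group differs in both its ring and its methyl link, so the compounds shown cannot separate these two parts of the change. A benzyl group on the same nitrogen would fill that gap, and a 2-(dimethylamino)ethyl group would show how an amine behaves at this position.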